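A few compounds are considered here, and "the series" means these few. Any claim that something is new, unique, unknown or untested is made for them only; others in the source may bear on it.

Compound 3 `CCC[C@H](N)[C@H]1COC(c2ccccc2)(c2ccccc2)O1` gives 3450 nM in a functional assay (brain) for displacement of a labelled ligand, with Rattus norvegicus as the target (a higher number here means a weaker inhibitor, a lower number a stronger inhibitor), which places it second highest of the three numbers measured, nearest compound 1 `CN1CCCC[C@H]1[C@H]1COC(c2ccccc2)(c2ccccc2)O1`, which gives 4400 nM, and furthest from compound 2 `NC[C@H]1COC(c2ccccc2)(c2ccccc2)O1`, which gives 1400 nM. The measured steps around it are a 1.3-fold lower number from compound 1 to compound 3 (0.11 log units; within the scatter), a 3.1-fold lower number from compound 1 to compound 2 (0.50 log units; beyond the scatter) and a 2.5-fold higher number from compound 2 to compound 3 (0.39 log units; beyond the scatter).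

Compound 4 `CNC[C@H]1COC(c2ccccc2)(c2ccccc2)O1` differs from compound 3 in one place: (methylamino)methyl in place of 1-aminobutyl on a saturated ring carbon. Among the measured compounds shown here, of the measured steps, the one from compound 2 to compound 3 bears most directly on it, since the removal of the propyl reverses that step, which was a 2.5-fold higher number from compound 2 to compound 3 (0.39 log units; beyond the scatter). For the measured compounds named here, no measured step isolates the methyl that enters on the amine nitrogen, so its contribution is unknown. Compound 4 is therefore expected to land close to compound 2, a modest step down from compound 3, a 2.3-fold lower number from compound 3 to compound 4 (0.36 log units; beyond the scatter). The estimate for compound 4 is 1500 nM, with a range from 600 nM to 4000 nM.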

Compound 4, inhibition constant: 7300 nM
Compound 4: middle estimate off by 4.9-fold (0.69 log units), on the low side, outside the stated range (above it).
By their numbers in this assay, from the lowest: compound 2; then compounds 3, 1 and 4 (each within the scatter of the next, the first and the last beyond it).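

In this assay, among the compounds shown here, a methyl on the amine nitrogen proves costly at this position, with a 5.2-fold higher number from compound 2 to compound 4 (0.72 log units; beyond the scatter), a change that no earlier step had isolated. The swap of 1-aminobutyl for (methylamino)methyl on the saturated ring carbon also gives a weaker inhibitor, with a 2.1-fold higher number from compound 3 to compound 4 (0.33 log units; beyond the scatter), whereas a 1.7-fold higher number from compound 1 to compound 4 (0.22 log units; within the scatter) leaves compound 1 and compound 4, the two that carry a methyl on the amine nitrogen, level with each other. No evidence is available to explain the effect of the methyl.

The compounds shown leave open whether an ethyl group or a second methyl on the amine nitrogen would raise the number further. They also leave open whether the same methyl would carry the same cost on the nitrogen of the 1-aminobutyl group.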